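Moving the halogen: compound 4 in the triazole-benzyl series

The compounds below may be only part of what the source reports. "The series", "measured", "known", "first", "only" and "open" are said of these compounds alone.

Three benzyl-substituted members of the shared core have been run in a functional assay on QGY7701 cells (Homo sapiens) for cytotoxicity, read by MTT assay, with a stated time of 48 h; a lower number here means a stronger inhibitor, a higher number a weaker inhibitor. Compound 1 `Cc1ccc(Cn2cc(COc3ccc4c(=O)ccoc4c3)nn2)cc1` gives 68500 nM. For compound 2 `O=c1ccoc2cc(OCc3cn(Cc4cccc(F)c4)nn3)ccc12` the read-out is a limit of the assay, > 100000 nM, as the upper cut-off (the limit of > 100000 nM in this assay, at which 1 of the 3 values shown sits). Compound 3 `O=c1ccoc2cc(OCc3cn(Cc4ccc(F)cc4)nn3)ccc12` gives 14400 nM, the lowest of the two numbers; the step of a 4.8-fold lower number from compound 1 to compound 3 (0.68 log units; beyond the scatter) separates it from compound 1, and the step of an at least 6.9-fold lower number from compound 2 to compound 3 (0.84 log units; beyond the scatter) from compound 2, while an at least 1.4-fold higher number from compound 1 to compound 2 (0.16 log units; that floor lies within the scatter) sits on the floor of the scatter.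

Compound 4 `O=c1ccoc2cc(OCc3cn(Cc4cccc(Cl)c4)nn3)ccc12` differs from compound 3 by 3-chlorophenyl in place of 4-fluorophenyl on a saturated chain carbon bound to an aromatic nitrogen. Among the measured compounds shown here, two measured steps bear on it. The step of an at least 6.9-fold lower number from compound 2 to compound 3 (0.84 log units; beyond the scatter) shows that a halogen at the 3-position of the benzyl ring, against the 4-position, costs potency in this assay by a modest amount at least. Chlorine against fluorine has no precedent in the set, so that part of the change cannot be weighed from these compounds. The expectation is therefore a step of a 4.9-fold higher number from compound 3 to compound 4 (0.69 log units; beyond the scatter), upward, on the order of the loss seen from compound 3 back to compound 2. Compound 4 is estimated at 70000 nM in this assay, within 20000 nM to 250000 nM, with a real chance that only a limit is returned.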

Compound 4, half-maximal inhibitory concentration: 28400 nM
For compound 4 the middle estimate is 2.5-fold (0.39 log units) above the measured one; measured number inside the range.
By their numbers in this assay, from the lowest: compounds 3 and 4 (each within the scatter of the next); then compound 1. At a limit, above all of these: compound 2.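

In this assay, chloro in place of fluoro on an aromatic carbon gives an at least 3.5-fold lower number from compound 2 to compound 4 (0.54 log units; beyond the scatter), so the poor read-out of the 3-fluorophenyl group does not extend to every halogen-bearing phenyl group at this place. Exchanging 4-fluorophenyl for 3-chlorophenyl gives a 2.0-fold higher number from compound 3 to compound 4 (0.29 log units; within the scatter), which leaves these two groups unresolved in this assay, while 3-chlorophenyl in place of 4-methylphenyl gives a 2.4-fold lower number from compound 1 to compound 4 (0.38 log units; beyond the scatter), so a second group joins 4-fluorophenyl on the favourable side of 4-methylphenyl. The read-out of compound 2 is a limit of the assay and not a number, so the step involving it is only a floor: the limit of > 100000 nM in this assay, at which 1 of the 4 values shown sits.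

The compounds shown do not separate the effect of chlorine from the effect of its place on the ring, a question that a 4-chlorophenyl group would address directly. Also open, going by these compounds, is how an amine or a carboxylic acid on the phenyl ring, or a longer chain in place of the benzyl carbon, would read in this assay.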